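The compounds below may be only part of what the source reports. "The series", "measured", "known", "first", "only" and "open" are said of these compounds alone.

Working notes on the series sharing the core of compound 1 (`CN(C)C(=O)c1cc2cnc(Nc3ccc(NC(=O)C4(C(=O)Nc5cccc(F)c5)CC4)cc3)nc2n1C1CCCC1`), read in a functional assay on T47D cells (Homo sapiens) for inhibition, read by CCK-8 assay, with a stated time of 72 h, tested at 1 uM; a lower number here means less inhibition of growth, a higher number more inhibition of growth at the concentration tested. Compound 1 gives -3.2%. Compound 2 (`CN(C)C(=O)c1cc2cnc(Nc3ccc(NC(=O)C4(C(=O)Nc5cccc(Cl)c5)CC4)cc3)nc2n1C1CCCC1`) gives 39.3%, and compound 3 (`CN(C)C(=O)c1cc2cnc(Nc3ccc(NC(=O)C4(C(=O)Nc5ccc(Cl)c(C(F)(F)F)c5)CC4)cc3)nc2n1C1CCCC1`) gives 6.9%. Compound 3 is therefore second highest of the three, with a number 10.1 percentage points higher from compound 1 to compound 3 (beyond the scatter) and a number 32.4 percentage points lower from compound 2 to compound 3 (beyond the scatter).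

The next member, compound 4 (`Cc1ccc(NC(=O)C2(C(=O)Nc3ccc(Nc4ncc5cc(C(=O)N(C)C)n(C6CCCC6)c5n4)cc3)CC2)cc1`), differs from compound 3 in one place: 4-methylphenyl in place of 4-chloro-3-(trifluoromethyl)phenyl on an amide-type nitrogen.

All three measured steps involve the group on this nitrogen. The largest is a number 42.5 percentage points higher from compound 1 to compound 2 (beyond the scatter), a swap of chloro for fluoro on an aromatic carbon. The step that removes the 4-chloro-3-(trifluoromethyl)phenyl group in favour of 3-chlorophenyl is the reverse of a number 32.4 percentage points lower from compound 2 to compound 3 (beyond the scatter). Among the compounds with values here, these steps run in both directions, and no measured compound carries 4-methylphenyl, so they set a wide range rather than a firm direction. Compound 3 at 6.9% lies near the low end of the series, and compound 2 at 39.3% shows that higher numbers occur with a different group here. A small upward step, not beyond the scatter, is therefore expected.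

The expected change is a number 8.1 percentage points higher from compound 3 to compound 4 (within the scatter). The estimated value for compound 4 is 15%, with an expected range from -5% to 38%.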

Compound 4, percent growth inhibition at one concentration: 47.9%
Compound 4: middle estimate off by 32.9 percentage points, on the low side; the measured number lies above the stated range.
By their numbers in this assay, from the lowest: compound 1; then compound 3; then compounds 2 and 4 (each within the scatter of the next).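

In this assay the change to 4-methylphenyl on the amide-type nitrogen gives a number 41 percentage points higher from compound 3 to compound 4 (beyond the scatter) and also a number 51.1 percentage points higher from compound 1 to compound 4 (beyond the scatter) so a ring carrying no halogen is enough to reach the upper level of this small set. The comparison with the 3-chlorophenyl compound gives a number 8.6 percentage points higher from compound 2 to compound 4 (within the scatter) and these two groups cannot be told apart here, which means that halogen on this ring does not sort the series: compound 2 carries one and stands with compound 4, whereas compound 1 and compound 3 also carry halogen and stand lower. Nothing available here bears on why this group swap moves growth inhibition so far.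

Compound 3 and compound 4 differ in both the chloro and trifluoromethyl groups of the one and the methyl group of the other, so the shown compounds do not say which feature of 4-chloro-3-(trifluoromethyl)phenyl goes with its low number. They also leave open how an unsubstituted phenyl, or a ring bearing a methoxy group or an amine, would read at this nitrogen, and whether the order among these compounds would hold at other concentrations.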